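The source may report more compounds than this note shows. Statements on the series, on what has been measured and on what is new or still open speak of the compounds shown alone.

Compound 1 `Cc1sc(-c2ccccc2)nc1CNc1ccc(OCC(=O)O)c(F)c1`: in an assay on CHO cells for agonist activity at Free fatty acid receptor 1 (Homo sapiens), read by FLIPR (a lower number here means that less compound is needed, a higher number that more compound is needed for the effect), compound 1 reaches only the limit > 10000 nM, a bound of the assay rather than a number.
Compound 2 `Cc1nc(-c2ccccc2)sc1COc1ccc2c(c1)OCC2CC(=O)O`: in this assay compound 2 gives 102 nM.
Compound 3 `Cc1nc(-c2ccc(Cl)cc2)sc1COc1ccc2c(c1)OCC2CC(=O)O`: in this assay compound 3 gives 105 nM.

Compound 3 carries the highest of the two numbers shown, yet its nearest neighbour is compound 2, and the single step between them, a 1.0-fold higher number from compound 2 to compound 3 (0.01 log units; within the scatter), lies within the scatter, so the two cannot be ranked. Among the compounds with values here, compound 1 differs from both in more than one place, so no step is drawn to it; it is recorded only at the limit (the limit of > 10000 nM in this assay, at which 1 of the 3 values shown sits).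

Compound 4 `COc1ccc(-c2nc(C)c(COc3ccc4c(c3)OCC4CC(=O)O)s2)cc1` continues from compound 3 by one change: methoxy in place of chloro on an aromatic carbon. Within the data shown here, only one measured step bears on this ring, the chloro for hydrogen exchange a 1.0-fold higher number from compound 2 to compound 3 (0.01 log units; within the scatter), which moved the number by nothing beyond the scatter. Among the measured compounds shown here, no measured step covers a methoxy here, so the reasoning rests on that one comparison alone. Compound 4 is therefore expected to land close to compound 3, with the step of a 1.0-fold higher number from compound 3 to compound 4 (0.02 log units; within the scatter) judged as within the scatter. The estimate for compound 4 is 110 nM, in a range from 40 nM to 300 nM.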

Compound 4, half-maximal effective concentration: 156 nM
Beside the measured number, compound 4's estimate is 1.4-fold (0.15 log units) below it, within the range that was stated.
By their numbers in this assay, from the lowest: compounds 2, 3 and 4 (each within the scatter of the next). At a limit, above all of these: compound 1.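

Within the data shown here, at this aromatic carbon, para to a large group, the earlier compounds showed only chloro against hydrogen, whereas methoxy brings in a carbon and an oxygen with one hydrogen-bond acceptor, and in this assay the exchange for chloro gives a 1.5-fold higher number from compound 3 to compound 4 (0.17 log units; within the scatter) with no departure from the scatter. Set against plain hydrogen at the same carbon, methoxy gives a 1.5-fold higher number from compound 2 to compound 4 (0.18 log units; within the scatter) and also stays within the scatter, which the chloro step had shown only for that one group. With hydrogen, chloro and methoxy now all measured here, compound 2, compound 3 and compound 4 cannot be ranked in this assay, so this position has so far shown no step beyond the scatter, whether the entering group is a single atom or the larger methoxy.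

As far as these compounds go, whether an amine, a carboxylic acid or a longer chain such as butoxy at this carbon would move the number beyond the scatter stays open. Nothing in the available evidence bears on this result or accounts for how closely these three values lie together.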